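This account rests on a few compounds, and the source may have more. Where it says the series, first, only, none or still open, it means among the compounds named here.

Among the compounds with values here, compound 2 `O=C(/C(=N/O)Nc1ccc(F)c(Br)c1)C1CCN(S(=O)(=O)Nc2ccccc2)CC1` sits at the top of the two numbers so far. In an assay on tissue (HeLa cells) for inhibition of Indoleamine 2,3-dioxygenase 1 (Homo sapiens), with a stated time of 48 h (a higher number here means a weaker inhibitor, a lower number a stronger inhibitor), compound 2 gives 150 nM, while compound 1 `NS(=O)(=O)N1CCC(C(=O)/C(=N/O)Nc2ccc(F)c(Br)c2)CC1` gives 45 nM. Within the data shown here, the one measured step, a 3.3-fold higher number from compound 1 to compound 2 (0.52 log units; beyond the scatter), describes the addition of a phenyl to a sulfonamide nitrogen that carries only hydrogen in compound 1, and it is the only step that bears on what follows.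

Compound 3 `O=C(/C(=N/O)Nc1ccc(F)c(Br)c1)C1CCN(S(=O)(=O)NCc2ccccc2)CC1` differs from compound 2 in one place: benzyl in place of phenyl on a sulfonamide nitrogen. This change keeps an aromatic ring on the sulfonamide nitrogen but inserts a carbon between it and the ring, so the measured step is only a partial guide: it tells how much adding a ring on that nitrogen cost, not what moving the ring one bond outward does. Both compound 2 and compound 3 carry a ring there, so a step near zero beyond the scatter is the most defensible expectation, with room for a modest move in either direction in this assay. Compound 3 is therefore expected at 150 nM, with a range from 50 nM to 450 nM, which means an expected step of no change at the digits printed from compound 2 to compound 3 (within the scatter).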

Compound 3, half-maximal inhibitory concentration: 262 nM
For compound 3 the middle estimate is 1.7-fold (0.24 log units) below the measured one; measured number inside the range.
By their numbers in this assay, from the lowest: compound 1; then compounds 2 and 3 (each within the scatter of the next).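

In this assay, the extra carbon that turns phenyl into benzyl on the sulfonamide nitrogen gives a 1.7-fold higher number from compound 2 to compound 3 (0.24 log units; within the scatter), so this change does not separate the two groups at this position. Compound 3 also shows that the earlier rise was not confined to phenyl: the benzyl group, set against the hydrogen of compound 1, gives a 5.8-fold higher number from compound 1 to compound 3 (0.77 log units; beyond the scatter), and this step, like a 3.3-fold higher number from compound 1 to compound 2 (0.52 log units; beyond the scatter), lies beyond the scatter, so both ring-bearing groups on that nitrogen stand apart from hydrogen in this short series. Nothing measured here explains why either group gives a higher number than hydrogen.

The compounds shown leave open whether a group with no ring on that nitrogen, such as methyl or a longer alkyl chain, would also give a higher number than hydrogen, or whether the aromatic ring is needed for that rise. They also leave open whether a phenethyl group, which would take the ring further out, or a methoxy or carboxylic acid on the ring of the benzyl group would keep the number where compound 2 and compound 3 stand.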